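The source may hold more compounds than are shown below. What is called first, only, known or untested is meant among the compounds shown, and "the series" means these compounds.

Compound 2 `C[C@@H](NC1CCN(CCCc2c[nH]c3ccc(-n4cnnc4)cc23)CC1)c1ccccc1` gives 0.4 nM in an assay on CHO cells for displacement of a labelled ligand from 5-hydroxytryptamine receptor 1D (Homo sapiens) (a higher number here means a weaker inhibitor, a lower number a stronger inhibitor), the lowest of the two numbers recorded so far; its nearest neighbour, compound 1 `CC(C)=CCCN(C)C1CCN(CCCc2c[nH]c3ccc(-n4cnnc4)cc23)CC1`, gives 2.6 nM in this assay. Compound 3 `CN(Cc1ccco1)C1CCN(CCCc2c[nH]c3ccc(-n4cnnc4)cc23)CC1` differs from compound 2 in one place: ((furan-2-yl)methyl)(methyl)amino in place of (1-phenylethyl)amino on a saturated ring carbon. Within the data shown here, the only measured step that bears on this position is a 6.5-fold lower number from compound 1 to compound 2 (0.81 log units; beyond the scatter), and in this group compound 3 resembles compound 1 more than compound 2. The number for compound 3 in this assay is therefore expected to rise, by an estimated 5.0-fold higher number from compound 2 to compound 3 (0.70 log units; beyond the scatter). The estimate for compound 3 is 2 nM, within a range from 0.6 nM to 7 nM.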

Compound 3, half-maximal inhibitory concentration: 9.3 nM
Compound 3: the middle estimate sits 4.7-fold (0.67 log units) below what was measured; measured number above the stated range.
By their numbers in this assay, from the lowest: compound 2; then compound 1; then compound 3.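

In this assay, replacing (1-phenylethyl)amino with ((furan-2-yl)methyl)(methyl)amino proves costly (a 23-fold higher number from compound 2 to compound 3 (1.37 log units; beyond the scatter)). With the methyl on the amine nitrogen kept, the chain end also matters: furan-2-yl gives a higher number than 3-methylbut-2-en-1-yl (a 3.6-fold higher number from compound 1 to compound 3 (0.55 log units; beyond the scatter)). No available measurement explains either step.

Going by these compounds, compound 2 and compound 3 differ at once in the aromatic ring, the amine hydrogen and the defined stereocentre, so which of these counts stays open. Also open, on these data alone, is how a benzyl(methyl)amino group would behave on this saturated ring carbon.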